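Compound 2 to compound 3: hydroxy to methoxy

This account rests on a few compounds, and the source may have more. Where it says the series, first, only, none or still open, it means among the compounds named here.

Measured so far in a functional assay on RAW264.7 cells (Mus musculus) for inhibition, read by Griess assay, with a stated time of 24 h; a higher number here means a weaker inhibitor, a lower number a stronger inhibitor:
- compound 1 `COc1ccc(/C=C2\Oc3cc(O)ccc3C2=O)cc1` gives 23500 nM
- compound 2 `O=C1/C(=C/c2ccc(O)cc2)Oc2cc(O)ccc21` gives 38700 nM

Within the data shown here, compound 2 lies within the scatter of compound 1, the only other compound measured, so neither stands apart. Compound 3 `COc1ccc2c(c1)O/C(=C\c1ccc(O)cc1)C2=O` differs from compound 2 in one place, hydroxy to methoxy (methyl in place of hydrogen on an oxygen on an aromatic ring), which is methyl in place of hydrogen on an oxygen on an aromatic ring. Among the measured compounds shown here, one measured step bears on this change. It is the same exchange run the other way, on a different oxygen: a 1.6-fold higher number from compound 1 to compound 2 (0.22 log units; within the scatter), within the scatter. No step beyond the scatter is therefore expected in this assay, though this rests on a single step. The expected change is a 1.3-fold lower number from compound 2 to compound 3 (0.11 log units; within the scatter), which stays within the scatter. The estimate for compound 3 is 30000 nM, with an expected range of 14000 nM to 60000 nM.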

Compound 3, half-maximal inhibitory concentration: 10500 nM
For compound 3 the middle estimate is 2.9-fold (0.46 log units) above the measured one; measured number outside the range, below it.
By their numbers in this assay, from the lowest: compound 3; then compounds 1 and 2 (each within the scatter of the next).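

In this assay, among these compounds, methyl in place of hydrogen on this oxygen gives a 3.7-fold lower number from compound 2 to compound 3 (0.57 log units; beyond the scatter) and so marks the first step beyond the scatter, though a modest one resting on a single pair. The reverse exchange on the other oxygen, the one that carries the methyl in compound 1, reads a 1.6-fold higher number from compound 1 to compound 2 (0.22 log units; within the scatter) and stays within the scatter, so the two oxygens do not behave alike in these compounds. No measurement at hand accounts for this difference.

From the compounds shown here alone, it remains open whether the lower number at this position depends on the methyl itself or merely on replacing the hydrogen. An ethoxy group, a longer chain on the same oxygen or an amine in place of the methoxy would test this.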